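The compounds below may be only part of what the source reports. "The series", "measured", "known", "first", "only" and "open" are said of these compounds alone.

Working notes on the series. In a functional assay on HL-60 cells (Homo sapiens) for antiproliferative activity, read by MTT assay, with a stated time of 72 h (a lower number here means a stronger inhibitor, a higher number a weaker inhibitor), compound 1 `NC1=NC2(CCSCC2)N(OCCCOc2cccc(Cl)c2)C(N)=N1` gives 260 nM and compound 3 `NC1=NC2(CCSCC2)N(OCCCOc2ccc(Br)cc2)C(N)=N1` gives 350 nM as measured values. Compound 2 `NC1=NC2(CCOCC2)N(OCCCOc2ccc(Cl)cc2)C(N)=N1` gives 330 nM and stands within the scatter of both, so these numbers set no order among the three.

The next step goes to compound 4 `NC1=NC2(CCOCC2)N(OCCCOc2ccccc2Br)C(N)=N1`, still unmeasured in this assay, with 2-bromophenyl in place of 4-chlorophenyl on an oxygen on a saturated carbon.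

For the measured compounds named here, only one measured step swaps the same kind of group at that place, 4-bromophenyl in place of 3-chlorophenyl: a 1.3-fold higher number from compound 1 to compound 3 (0.13 log units; within the scatter). That step stays within the scatter. Going by the values given here, no measured compound carries 2-bromophenyl, so this evidence is thin and the range is kept wide.

Among the compounds with values here, with only that small step to go on, no change beyond the scatter is expected, and the estimate is a 1.1-fold higher number from compound 2 to compound 4 (0.03 log units; within the scatter) in this assay. For compound 4 the expected value is 350 nM, with an estimated range of 150 nM to 800 nM.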

Compound 4, half-maximal inhibitory concentration: 610 nM
Compound 4: middle estimate off by 1.7-fold (0.24 log units), on the low side, within the range that was stated.
By their numbers in this assay, from the lowest: compounds 1, 2, 3 and 4 (each within the scatter of the next, the first and the last beyond it).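

In this assay, 2-bromophenyl in place of 4-chlorophenyl on an oxygen on a saturated carbon gives a 1.8-fold higher number from compound 2 to compound 4 (0.27 log units; within the scatter). For the compounds shown here, this is a second step at this place that stays within the scatter, now on the core of compound 2 and with 2-bromophenyl, a group no earlier compound carried, so the place accepts this swap without a change that can be read. No measurement at hand bears on the reason for this result.

The step changes the halogen and its place on the phenyl ring together, and no pair shown separates the two. Also open, on these data alone, is whether an amine or a carboxylic acid on the phenyl ring, or a longer chain before the phenoxy group, would carry the number beyond the scatter.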